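The source may report more compounds than this note shows. Statements on the series, on what has been measured and on what is new or still open speak of the compounds shown alone.

In a functional assay on CNE-2 cells (Homo sapiens) for antiproliferative activity, read by sulforhodamine B assay, with a stated time of 48 h (a higher number here means a weaker inhibitor, a lower number a stronger inhibitor), compound 1 `COc1ccc(C(=O)/C=C/c2ccccc2-c2ccc(F)cc2)cc1` gives 9000 nM, compound 2 `COc1ccc(C(=O)/C=C/c2ccccc2-c2ccc(F)cc2)cc1OC` gives 7600 nM and compound 3 `COc1ccc(C(=O)/C=C/c2ccccc2-c2ccc(F)nc2)cc1OC` gives 17000 nM. Compound 2 thus stands at the low end of the three numbers, together with compound 1. Compound 4 `COc1cc(C(=O)/C=C/c2ccccc2-c2ccc(F)cc2)ccc1O` differs from compound 2 by hydrogen in place of methyl on an oxygen on an aromatic ring. Going by the values given here, no measured step makes this change. The closest is a 1.2-fold lower number from compound 1 to compound 2 (0.07 log units; within the scatter), for methoxy in place of hydrogen on an aromatic carbon, and it stays within the scatter. The other, a 2.2-fold higher number from compound 2 to compound 3 (0.35 log units; beyond the scatter), is modest and concerns a different part of the molecule. In this assay, the expected outcome is therefore no shift beyond the scatter, an estimated 1.1-fold higher number from compound 2 to compound 4 (0.02 log units; within the scatter). For compound 4 the estimated value is 8000 nM, with an expected range from 3500 nM to 18000 nM.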

Compound 4, half-maximal inhibitory concentration: 4800 nM
Beside the measured number, compound 4's estimate is 1.7-fold (0.22 log units) above it; the range from low to high includes it.
By their numbers in this assay, from the lowest: compounds 4, 2, 1 and 3 (each within the scatter of the next, the first and the last beyond it).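

Cutting the methyl from this oxygen, methoxy to hydroxy, gives a 1.6-fold lower number from compound 2 to compound 4 (0.20 log units; within the scatter) in this assay, so this oxygen keeps the number within the scatter with or without its methyl. The earlier compounds shown here had varied the other methoxy and the fluorinated ring but left this group untouched. Nothing available here explains this result. As far as these compounds go, whether an ethoxy or an amine in this place would also leave the number within the scatter stays open. So does whether hydroxy in place of methoxy would give the same result on compound 1.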